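Benzyl for pentan-3-yl on a shared oxazolidinedione core

This account rests on a few compounds, and the source may have more. Where it says the series, first, only, none or still open, it means among the compounds named here.

Measured compounds:
Compound 1 `CCC(CC)C(/C=C1\OC(=O)NC1=O)c1ccc(-c2ccc3cccc(F)c3c2)[nH]c1=O` in a functional assay on CHO cells for antagonist activity at prostaglandin E2 receptor EP3 subtype (Homo sapiens), read by cAMP accumulation, with a stated time of 30 min (a higher number here means a weaker inhibitor, a lower number a stronger inhibitor), gives 23 nM.
Compound 2 `C/C(=C1/OC(=O)NC1=O)C(c1ccc(-c2ccc3cccc(F)c3c2)[nH]c1=O)C(C)C` in this assay gives 39 nM.
Compound 3 `CC(C)/C(=C1/SC(=O)NC1=O)c1ccc(-c2ccc3cccc(F)c3c2)[nH]c1=O` in this assay gives 63 nM.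

Compound 1 holds the lowest of the three numbers in this assay. Compound 2 sits close to it, within the usual scatter, so no order between compound 1 and compound 2 can be read from these two values. Compound 3 lies beyond the scatter from compound 1, the only gap here that is more than noise.

Compound 4 `O=C1NC(=O)/C(=C/C(Cc2ccccc2)c2ccc(-c3ccc4cccc(F)c4c3)[nH]c2=O)O1` differs from compound 1 in one place: benzyl in place of pentan-3-yl on a saturated chain carbon bound to an aromatic carbon and a double-bonded chain carbon. Within the data shown here, no measured pair here shows such a swap, so its effect is unknown. Compound 2 and compound 3 carry other branched groups and do not speak to this change either.

Compound 4 is therefore expected to stay near compound 1, with a step of a 1.7-fold higher number from compound 1 to compound 4 (0.24 log units; within the scatter) that likely falls within the scatter. The estimate for compound 4 in this assay is 40 nM, with a range from 10 nM to 160 nM.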

Compound 4, half-maximal inhibitory concentration: 200 nM
Compound 4: middle estimate off by 5.0-fold (0.70 log units), on the low side; measured number outside the range, above it.
By their numbers in this assay, from the lowest: compounds 1, 2 and 3 (each within the scatter of the next, the first and the last beyond it); then compound 4.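

In this assay, benzyl in place of pentan-3-yl on a saturated chain carbon bound to an aromatic carbon and a double-bonded chain carbon gives an 8.7-fold higher number from compound 1 to compound 4 (0.94 log units; beyond the scatter), so this position does not treat these two carbon-only groups alike. Among these compounds, the earlier compounds carried only open-chain branched groups, and this pair is the first to show a single swap at this place, with an aromatic ring entering and the number moving clearly upward. Nothing at hand accounts for this step, which rests on one pair of compounds.

Going by these compounds, whether the aromatic ring or simply the larger group drives the step stays open, and a cyclohexylmethyl group at the same carbon would separate the two. A shorter chain such as isopropyl, or a longer one such as hexan-3-yl, on the shared core would also show how far open-chain groups are accepted here.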